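The source may hold more compounds than are shown below. What is called first, only, known or untested is meant among the compounds shown, and "the series" means these compounds.

Compound 1 `COc1ccc(CN2C(=O)C(=O)c3cc(-c4cccc(OC)c4)ccc32)cc1`, compound 2 `COc1ccc(CN2C(=O)C(=O)c3cc(-c4ccc(OC(C)C)cc4)ccc32)cc1` and compound 3 `COc1ccc(CN2C(=O)C(=O)c3cc(-c4ccc(C#N)cc4)ccc32)cc1` share one core and differ only in the aryl group attached to it. In a functional assay on HepG2 cells (Homo sapiens) for antiproliferative activity, read by MTT assay, with a stated time of 48 h (on this read-out lower numbers stand for stronger inhibition and higher numbers for weaker inhibition), compound 1 gives 1890 nM. In this assay compound 3 gives 890 nM, the lowest of the two numbers shown. For compound 2 the read-out in this assay is only a limit, > 10000 nM, and not a number (the limit of > 10000 nM in this assay, at which 1 of the 3 values shown sits). The step of a 2.1-fold lower number from compound 1 to compound 3 (0.33 log units; beyond the scatter) is modest, the step of an at least 11-fold lower number from compound 2 to compound 3 (1.05 log units; beyond the scatter) is large, and the step of an at least 5.2-fold higher number from compound 1 to compound 2 (0.72 log units; beyond the scatter) runs the other way.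

Compound 4 `COc1ccc(CN2C(=O)C(=O)c3cc(-c4ccc(C(F)(F)F)cc4)ccc32)cc1` is not yet measured. It differs from compound 3 by trifluoromethyl in place of cyano on an aromatic carbon. Within the data shown here, no measured step exchanges cyano for trifluoromethyl; the closest, an at least 11-fold lower number from compound 2 to compound 3 (1.05 log units; beyond the scatter), concerned an isopropoxy group instead, so the measured steps give little direct guidance here. For compound 4 a step of a 1.7-fold higher number from compound 3 to compound 4 (0.23 log units; within the scatter) in this assay is expected, close to the scatter. Compound 4 is therefore estimated at 1500 nM, within a range from 500 nM to 5000 nM.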

Compound 4, half-maximal inhibitory concentration: 820 nM
For compound 4 the middle estimate is 1.8-fold (0.26 log units) above the measured one; the range from low to high includes it.
By their numbers in this assay, from the lowest: compounds 4 and 3 (each within the scatter of the next); then compound 1. At a limit, above all of these: compound 2.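

In this assay, trifluoromethyl and cyano on this aromatic carbon, para to a large group, cannot be told apart: a 1.1-fold lower number from compound 3 to compound 4 (0.04 log units; within the scatter). Thus, in this pair, the hydrogen-bond acceptor counted on cyano is not needed to keep the read-out at this level, and the 4-(trifluoromethyl)phenyl group joins 4-cyanophenyl in giving a lower number than 3-methoxyphenyl: a 2.3-fold lower number from compound 1 to compound 4 (0.36 log units; beyond the scatter). The large step of an at least 12-fold lower number from compound 2 to compound 4 (1.08 log units; beyond the scatter) starts from a limit and not from a number: the limit of > 10000 nM in this assay, at which 1 of the 4 values shown sits.

As far as these compounds go, how an amine or a carboxylic acid in the same place would read remains open. From the compounds shown here alone, it is also open whether a shorter ether, such as ethoxy, would read closer to compound 2 or to compound 4.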